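Solubility notes: triazole in place of succinimide

The compounds below may be only part of what the source reports. "The series", "measured", "known", "first", "only" and "open" are said of these compounds alone.

Compound 3 `O=C1CCC(=O)N1C[C@H]1CN(c2ccc(-n3cc(-c4ccccn4)cn3)c(F)c2)C(=O)O1` carries a 2,5-dioxopyrrolidin-1-yl group on a saturated chain carbon bound to a saturated ring carbon. In a physicochemical assay for solubility, read by HPLC, with a stated time of 24 h (a lower number here means a less soluble compound, a higher number a more soluble compound), compound 3 gives 45300 nM, the lowest of the two numbers in hand. Among the measured compounds shown here, its nearest measured neighbour is compound 1 `CN1CCN(C[C@H]2CN(c3ccc(-n4cc(-c5ccccn5)cn4)c(F)c3)C(=O)O2)CC1`, which in this assay gives 1690000 nM; the single change between them, a 37-fold lower number from compound 1 to compound 3 (1.57 log units; beyond the scatter), is the only measured step in the set. Compound 2 `O=C1O[C@@H](CN2CCC(c3ccc(F)cc3)CC2)CN1c1ccc(-n2cc(-c3ccccn3)cn2)c(F)c1` is reported in this assay only as a limit, <= 19400 nM, and gives no number (the limit of <= 19400 nM in this assay, at which 1 of the 3 values shown sits).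

Compound 4 `O=C1O[C@@H](Cn2ccnn2)CN1c1ccc(-n2cc(-c3ccccn3)cn2)c(F)c1` differs from compound 3 in one place: 1H-1,2,3-triazol-1-yl in place of 2,5-dioxopyrrolidin-1-yl on a saturated chain carbon bound to a saturated ring carbon. For the measured compounds named here, no measured step covers this exchange; the step from compound 1 to compound 3 concerns a different entering group and therefore serves only as a reference for how far one change at this position can move the read-out. Without a closer precedent, compound 4 is expected to remain near compound 3, with a step of a 1.3-fold higher number from compound 3 to compound 4 (0.12 log units; within the scatter) that stays within the scatter. The expected value for compound 4 in this assay is 60000 nM, with a range from 20000 nM to 200000 nM.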

Compound 4, solubility: 247000 nM
Estimate against measurement, compound 4: 4.1-fold (0.61 log units) below, outside the stated range (above it).
By their numbers in this assay, from the lowest: compound 3; then compound 4; then compound 1. At a limit, below all of these: compound 2.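

With a third number in this assay, this position on a saturated chain carbon bound to a saturated ring carbon shows that the read-out also moves beyond the scatter when one group without net charge or hydrogen-bond donors replaces another: a 5.5-fold higher number from compound 3 to compound 4 (0.74 log units; beyond the scatter). The 1H-1,2,3-triazol-1-yl group, a five-membered aromatic ring, recovers part of the gap left by the 2,5-dioxopyrrolidin-1-yl group but does not reach the number given by the 4-methylpiperazin-1-yl group, with a 6.8-fold lower number from compound 1 to compound 4 (0.84 log units; beyond the scatter) still beyond the scatter. The compounds shown hold no measurement that accounts for either step.

Steps to compound 2 cannot be read, as its entry in this assay is a limit. On these data alone, it remains open whether a primary amine, a carboxylic acid or a 1H-1,2,4-triazol-1-yl group at this place would give a number nearer to compound 1 or to compound 3, and whether a longer chain carrying the 1H-1,2,3-triazol-1-yl group would keep the order seen here.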